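Heptyl for difluoromethoxy on the sulfonamide aryl ring

A few compounds are considered here, and "the series" means these few. Any claim that something is new, unique, unknown or untested is made for them only; others in the source may bear on it.

Three analogues sharing one core have been measured in a functional assay on M21 cells (Homo sapiens) for antiproliferative activity, read by sulforhodamine B assay, with a stated time of 48 h; a lower number here means a stronger inhibitor, a higher number a weaker inhibitor. Compound 1 `O=C1NCCN1c1ccc(S(=O)(=O)Nc2cccc(Br)c2)cc1` gives 59 nM; compound 3 `O=C1NCCN1c1ccc(S(=O)(=O)Nc2ccc(F)c(F)c2)cc1` gives 220 nM; compound 2 `O=C1NCCN1c1ccc(S(=O)(=O)Nc2ccc(OC(F)F)cc2)cc1` gives 410 nM. Compound 2 stands with the highest of the three numbers, though its gap to compound 3 is within the scatter, while its gap to compound 1 is beyond it. Among the compounds with values here, the only step between measured compounds that differ in one place is a 3.7-fold higher number from compound 1 to compound 3 (0.57 log units; beyond the scatter).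

Compound 4 `CCCCCCCc1ccc(NS(=O)(=O)c2ccc(N3CCNC3=O)cc2)cc1` is not yet measured. It differs from compound 2 by heptyl in place of difluoromethoxy on an aromatic carbon. Within the data shown here, no measured step touches this group: the step from compound 1 to compound 3 concerns halogens, not a heptyl chain, and gives no guide here. With nothing to carry over, no step beyond the scatter is expected in this assay. Compound 4 is therefore estimated at 300 nM, with a range of 80 nM to 1200 nM. The expected step is a 1.4-fold lower number from compound 2 to compound 4 (0.14 log units; within the scatter), within the scatter.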

Compound 4, half-maximal inhibitory concentration: > 1000 nM
Compound 4 was reported as a limit; the forecaster's own chance of this, stated with the estimate: 5%; middle value at least 3.3-fold (0.52 log units) from the limit.
By their numbers in this assay, from the lowest: compound 1; then compounds 3 and 2 (each within the scatter of the next). At a limit, above all of these: compound 4.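

In this assay compound 4 stands only as a limit, > 1000 nM: the limit of > 1000 nM in this assay, at which 1 of the 4 values shown sits. Heptyl in place of difluoromethoxy on this aromatic carbon, para to a large group, gives an at least 2.4-fold higher number from compound 2 to compound 4 (0.38 log units; beyond the scatter), the first step in the series that bears on a carbon chain at this place. The earlier compounds shown here carry only halogens or difluoromethoxy on the ring, and they gave no sign that heptyl would be tolerated less well than difluoromethoxy in this assay series.

Going by these compounds, how far the number of compound 4 lies past its limit stays open, so the step has a lower bound only. On these data alone, whether the loss tracks chain length or the loss of the oxygen also stays open: a shorter chain such as propyl, a methoxy group or an amine at this place would separate the two.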